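The source may report more compounds than this note shows. Statements on the series, on what has been measured and on what is new or still open speak of the compounds shown alone.

Working notes on the series.

Of the compounds shown here, three with a shared core have been measured. Compound 1 `c1nnc2nnc(N3CCCC3)nn12` carries a pyrrolidine on the core, compound 2 `OCC(CO)(CO)Nc1nnc2nncn2n1` a tris(hydroxymethyl)methylamino group, and compound 3 `CC(=O)N1CCN(c2nnc3nncn3n2)CC1` an acetyl-piperazine. In a functional assay on HL-60 cells (Homo sapiens) for inhibition, read by MTT assay, with a stated time of 72 h (on this read-out lower numbers stand for stronger inhibition and higher numbers for weaker inhibition), compound 1 gives 24400 nM. Compound 2 reaches only a limit of the assay in this assay, recorded as > 100000 nM. Compound 3 gives 14700 nM in this assay, the lower of the two numbers on hand, but the gap to compound 1 is within the scatter, so the two cannot be set apart on these data. For the measured compounds named here, the one further value on hand is the limit noted for compound 2 (the limit of > 100000 nM in this assay, at which 1 of the 3 values shown sits).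

Compound 4 `CC(C)(C)C(=O)N1CCN(c2nnc3nncn3n2)CC1` is the next member and is yet to be measured. It differs from compound 3 in one place: tert-butyl in place of methyl on a carbonyl carbon. Going by the values given here, no step between two measured compounds is available to anchor this change, and the acetyl-to-(tert-butyl)carbonyl change is the only variation at the amide-type nitrogen in a ring. Within this series the expectation is a step of no size beyond the scatter, in either direction. The expected step of a 1.2-fold lower number from compound 3 to compound 4 (0.09 log units; within the scatter) is accordingly a small one. Compound 4 is expected to give 12000 nM in this assay, within a range from 4000 nM to 40000 nM.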

Compound 4, half-maximal inhibitory concentration: 1380 nM
Beside the measured number, compound 4's estimate is 8.7-fold (0.94 log units) above it; the whole stated range lies above it.
By their numbers in this assay, from the lowest: compound 4; then compounds 3 and 1 (each within the scatter of the next). At a limit, above all of these: compound 2.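

For the compounds shown here, on a carbonyl carbon whose other neighbours are an amide-type nitrogen in a ring, tert-butyl in place of methyl gives the first readable step: in this assay, the change yields an 11-fold lower number from compound 3 to compound 4 (1.03 log units; beyond the scatter) and so moves the number well beyond the scatter. The earlier compounds shown here offered no step between measured members, so they could not show that the read-out responds to a change in one place, or that this position on the acyl group is one where it does. Nothing on hand gives a measured property that bears on this step, and it stands as an observation only.

With only acetyl and (tert-butyl)carbonyl shown at this position, a single step cannot tell whether an isopropyl, a cyclopropyl or a phenyl group on the same carbonyl carbon would fall nearer to compound 3 or to compound 4. Also open, on these data alone, is whether the step carries over to other cell lines, since all the values shown come from one assay on one cell type.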